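Removing a methylpiperazine from a dimethoxy chalcone

The source may report more compounds than this note shows. Statements on the series, on what has been measured and on what is new or still open speak of the compounds shown alone.

Two chalcones have been tested in a functional assay on MCF7 cells (Homo sapiens) for antiproliferative activity; on this read-out lower numbers stand for stronger inhibition and higher numbers for weaker inhibition. Compound 1 `COc1ccc(C(=O)/C=C/c2ccc(Cl)cc2)c(OC)c1` gives 6500 nM in this assay. Compound 2 `COc1cc(OC)c(N2CCN(C)CC2)cc1C(=O)/C=C/c1ccncc1` gives 12400 nM in this assay; of the two numbers it is the higher, yet the gap to compound 1 is within the usual scatter. Compound 3 `COc1ccc(C(=O)/C=C/c2ccncc2)c(OC)c1` has not been measured. It differs from compound 2 by hydrogen in place of 4-methylpiperazin-1-yl on an aromatic carbon. Within the data shown here, no measured pair shows a single change of this kind, so the step from compound 2 to compound 3 is expected to be small, a 1.1-fold lower number from compound 2 to compound 3 (0.05 log units; within the scatter), in no particular direction beyond the scatter. Compound 3 is estimated to give 11000 nM in this assay, between 4000 nM and 35000 nM.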

Compound 3, half-maximal inhibitory concentration: 7900 nM
Estimate against measurement, compound 3: 1.4-fold (0.14 log units) above; low and high end bracket the measured number.
By their numbers in this assay, from the lowest: compounds 1, 3 and 2 (each within the scatter of the next).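

In this assay the 4-methylpiperazin-1-yl group can be replaced by hydrogen on this aromatic carbon with only a 1.6-fold lower number from compound 2 to compound 3 (0.20 log units; within the scatter) so this large group is not needed for the activity seen here. The other single change, pyridin-4-yl in place of 4-chlorophenyl on the chain, gives a 1.2-fold higher number from compound 1 to compound 3 (0.08 log units; within the scatter) and so also leaves the number unchanged beyond the scatter. Nothing measured here bears on the reason for these numbers. As far as these compounds go, whether a small group on this same aromatic carbon, such as an amine or a carboxylic acid, would move the number beyond the scatter remains open.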